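The compounds below may be only part of what the source reports. "The series", "measured", "known", "first", "only" and "open" are said of these compounds alone.

Of the compounds shown here, two sharing one core have been measured so far in a functional assay on MOLT-4 cells (Homo sapiens); a higher number here means a weaker inhibitor, a lower number a stronger inhibitor. There, compound 1 (`CN(C)CC1CCC/C(=C\c2ccc(OC(=O)/C=C/c3ccc(F)cc3)cc2)C1=O`) gives 3780 nM and compound 2 (`CN(C)CC1CCC/C(=C\c2ccc(OC(=O)/C=C/c3ccc(Br)cc3)cc2)C1=O`) gives 3060 nM. Among the compounds with values here, the only measured step is a 1.2-fold lower number from compound 1 to compound 2 (0.09 log units; within the scatter), which leaves compound 2 level with the one other value available.

Compound 3 (`CN(C)CC1CCC/C(=C\c2ccc(OC(=O)c3ccccc3)cc2)C1=O`) has not yet been measured. It departs from compound 2 in one place, on a carbonyl carbon, where phenyl takes the place of 2-(4-bromophenyl)ethenyl: phenyl in place of 2-(4-bromophenyl)ethenyl on a carbonyl carbon. The measured step bears on this only weakly. It exchanged fluoro for bromo on an aromatic carbon, whereas here the whole 2-(4-bromophenyl)ethenyl group leaves, along with its double bond outside aromatic rings. Within the data shown here, no measured compound shows what such a loss does, so no shift beyond the scatter can be expected in this assay, and no direction can be favoured with confidence. The expectation therefore stays anchored on compound 2 at 3060 nM, with a wide range. The expected change is small, an estimated 1.1-fold higher number from compound 2 to compound 3 (0.06 log units; within the scatter). Compound 3 is estimated at 3500 nM, with an expected range of 1200 nM to 10000 nM.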

Compound 3, half-maximal inhibitory concentration: 24100 nM
The estimate for compound 3 lay 6.9-fold (0.84 log units) below the measured number; the measured number lies above the stated range.
By their numbers in this assay, from the lowest: compounds 2 and 1 (each within the scatter of the next); then compound 3.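

At the carbonyl carbon, the group attached matters far more in this assay than the earlier halogen exchange suggested: with phenyl in place of 2-(4-bromophenyl)ethenyl, the result is a 7.9-fold higher number from compound 2 to compound 3 (0.90 log units; beyond the scatter), so compound 3 is the weaker inhibitor. The fluoro compound gives the same picture, with phenyl in place of 2-(4-fluorophenyl)ethenyl producing a 6.4-fold higher number from compound 1 to compound 3 (0.80 log units; beyond the scatter), and both steps lie beyond the scatter, whereas swapping the halogen alone did not. Nothing available on these compounds accounts for this loss of inhibition.

The compounds shown leave open which part of the departing group carries the difference, as the double bond, the two extra carbons and the halogen all leave together in these steps. Going by these compounds, a 4-bromophenyl group directly on the carbonyl carbon or a saturated 2-(4-bromophenyl)ethyl chain there would begin to separate these parts, and how an amine or a carboxylic acid in place of the halogen would read in this assay also remains unknown.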